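Ester Aromatic Swap on a Triterpenoid Scaffold

The compounds below may be only part of what the source reports. "The series", "measured", "known", "first", "only" and "open" are said of these compounds alone.

Compound 1 `CC1=CCC2C(CC[C@@]2(C)O)C(C)(C)C1CC[C@@H]1[C@@]2(C)CCC(=O)C(C)(C)O[C@@H]2CC[C@]1(C)O`: > 50000 nM
Compound 2 `CC1=CC[C@H]2[C@H](CC[C@]2(C)O)C(C)(C)[C@@H]1CC[C@H]1[C@]2(C)CC[C@H](OC(=O)c3ccncc3)C(C)(C)O[C@H]2CC[C@@]1(C)O`: 18000 nM

In a functional assay on MDA-MB-231 cells (Homo sapiens) for antiproliferative activity, read by MTT assay, with a stated time of 72 h (a higher number here means a weaker inhibitor, a lower number a stronger inhibitor), compound 1 reaches only the assay limit (the limit of > 50000 nM in this assay, at which 1 of the 2 values shown sits). Compound 2 gives 18000 nM, the one actual number shown. Compound 3 `COc1ccc(C(=O)O[C@H]2CC[C@]3(C)[C@H](CC[C@@](C)(O)[C@H]3CC[C@@H]3C(C)=CC[C@H]4[C@H](CC[C@]4(C)O)C3(C)C)OC2(C)C)cc1` differs from compound 2 in a single place (4-methoxyphenyl in place of pyridin-4-yl on a carbonyl carbon). Among the measured compounds shown here, no measured pair shows what such a swap does here. Compound 3 is expected to sit close to compound 2, with a step of a 1.2-fold lower number from compound 2 to compound 3 (0.08 log units; within the scatter) that stays within the scatter. The estimate for compound 3 in this assay is 15000 nM, between 5000 nM and 45000 nM.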

Compound 3, half-maximal inhibitory concentration: 30600 nM
Beside the measured number, compound 3's estimate is 2.0-fold (0.31 log units) below it; low and high end bracket the measured number.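

On this carbonyl carbon, 4-methoxyphenyl in place of pyridin-4-yl gives a 1.7-fold higher number from compound 2 to compound 3 (0.23 log units; within the scatter) in this assay. The two rings therefore cannot be told apart here, so a ring nitrogen is not required at this position for activity at this level. No information given here bears on the size of this step. On these data alone, whether a longer carbon chain or a ring carrying an amine on the same carbonyl carbon would move the number beyond the scatter remains open.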